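The source may hold more compounds than are shown below. What is called first, only, known or untested is meant among the compounds shown, and "the series" means these compounds.

Measured so far in an ADME assay on cells (Erythrocyte, Homo sapiens), read by hemolysis, with a stated time of 1 h; on this read-out higher numbers stand for weaker inhibition and lower numbers for stronger inhibition:
- Compound 1 `CC(=NNC(=S)Nc1cccc(I)c1)c1ccccn1`: > 10000 nM
- Compound 2 `CC(=NNC(=S)Nc1ccc(I)cc1)c1ccccn1`: > 10000 nM
- Compound 3 `CC(=NNC(S)=Nc1ccccc1Cl)c1ccccn1`: > 10000 nM

None of these three entries is a true number, and the whole set sits at one ceiling: the limit of > 10000 nM in this assay, at which 3 of the 3 values shown sit. Compound 2 gives > 10000 nM, which is a limit of the assay. No order among the three compounds can be read from such entries.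

Compound 4 `CC(=NNC(=S)Nc1ccc([N+](=O)[O-])cc1)c1ccccn1` has not yet been measured. It keeps the rest of compound 2 and changes a single group: nitro in place of iodo on an aromatic carbon. In words, this is nitro in place of iodo on an aromatic carbon, para to a large group.

Among the compounds with values here, no measured pair shows what a swap of this kind does in this assay. Within the data shown here, the only guide is that all three measured compounds reach the same limit, although they differ in the groups on that ring. The expected change is a step that the limit leaves unreadable from compound 2 to compound 4, which means none beyond the scatter and no favoured direction. For compound 4 the estimated value is 12000 nM, with an expected range of 7000 nM to 30000 nM.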

Compound 4, half-maximal inhibitory concentration: > 10000 nM
Compound 4: only a limit was reported; the forecaster's own chance of this, stated with the estimate: 85%; the middle value is on the limit's open side.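

In this assay, within the data shown here, compound 2 and compound 4 both give only a limit, so no step between them can be read for nitro in place of iodo: the limit of > 10000 nM in this assay, at which 4 of the 4 values shown sit. The compounds shown leave open how far each lies beyond that limit and how they would rank there.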